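Adding a Methoxy Group: Expected Effect on Cytotoxicity

This account rests on a few compounds, and the source may have more. Where it says the series, first, only, none or still open, it means among the compounds named here.

Of the compounds shown here, three built on a shared core have been measured in an ADME assay on MT2 cells (Homo sapiens) for cytotoxicity; on this read-out higher numbers stand for lower toxicity in this test and lower numbers for higher toxicity in this test. Compound 1 `CC(C)=CCOc1cc(Nc2ncnc(N)n2)ccc1Cl` gives 48000 nM. Compound 2 `CC(C)=CCOc1cc(Nc2nccc(N)n2)ccc1Cl` gives 500 nM, and compound 3 `CSc1ccnc(Nc2ccc(Cl)c(OCC=C(C)C)c2)n1` gives 2800 nM. Compound 2 thus stands at the lowest number of the three; its nearest neighbour is compound 3 and its furthest is compound 1, with a 96-fold lower number from compound 1 to compound 2 (1.98 log units; beyond the scatter) and a 5.6-fold higher number from compound 2 to compound 3 (0.75 log units; beyond the scatter) both lying beyond the scatter.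

Compound 4 `COc1cc(N)nc(Nc2ccc(Cl)c(OCC=C(C)C)c2)n1` differs from compound 2 in one place: methoxy in place of hydrogen on an aromatic carbon. Going by the values given here, no measured step introduces a methoxy group, so the closest guides are the two changes made on the core of compound 2, the exchange of the six-membered aromatic ring, a 96-fold lower number from compound 1 to compound 2 (1.98 log units; beyond the scatter), and the exchange at the amino group, a 5.6-fold higher number from compound 2 to compound 3 (0.75 log units; beyond the scatter). Both alterations returned numbers higher than compound 2 in this assay, the first by a large margin and the second by a modest one. As compound 2 already holds the lowest number of the set, a modest rise is expected for compound 4, with wide uncertainty, since a methoxy group has no direct precedent among these compounds. Compound 4 is estimated at 1500 nM, within a range of 400 nM to 6000 nM. The expected step is a 3.0-fold higher number from compound 2 to compound 4 (0.48 log units; beyond the scatter).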

Compound 4, half-maximal cytotoxic concentration: 19000 nM
Estimate against measurement, compound 4: 13-fold (1.10 log units) below; the measured number lies above the stated range.
By their numbers in this assay, from the lowest: compound 2; then compound 3; then compound 4; then compound 1.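

Going by these compounds alone, the aromatic carbon next to the ring nitrogen of the shared core proves far more sensitive in this assay than the earlier compounds could reveal, as none of them carries a change at this position: methoxy in place of hydrogen gives a large rise (a 38-fold higher number from compound 2 to compound 4 (1.58 log units; beyond the scatter)), which means lower toxicity in this test. An entering group of only 2 heavy atoms, with no ring and no net charge, is therefore enough to take the core of compound 2 well away from the lowest number of the set. This step is also larger than the modest one at the amino group (a 5.6-fold higher number from compound 2 to compound 3 (0.75 log units; beyond the scatter)), and it is graded large, like the exchange that separates compound 1 from compound 2 (a 96-fold lower number from compound 1 to compound 2 (1.98 log units; beyond the scatter)), so the two changes made on the six-membered aromatic ring of compound 2 both raise the number, but this one does so at a single carbon.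

From the compounds shown here alone, whether a methyl group, a hydroxyl group, a chlorine atom or a longer ethoxy chain on this same carbon would move the number as far remains open, as does whether methoxy would act alike with methylsulfanyl in place of amino. Nothing shown offers measured evidence on what lies behind the rise.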